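Benzyl variation on a shared nucleoside core: notes toward compound 4

This account rests on a few compounds, and the source may have more. Where it says the series, first, only, none or still open, it means among the compounds named here.

Compound 1 `OC[C@H]1O[C@@H](n2cnc3c(NCc4cccc(F)c4)ncnc32)[C@H](O)[C@@H]1O` reaches only a limit in a functional assay on HOS cells (Homo sapiens) for antiproliferative activity, with a stated time of 72 h; a higher number here means a weaker inhibitor, a lower number a stronger inhibitor: compound 1 gives > 166000 nM.
Compound 2 `OC[C@H]1O[C@@H](n2cnc3c(NCc4ccccc4Br)ncnc32)[C@H](O)[C@@H]1O` likewise reaches only a limit in this assay: compound 2 gives > 166000 nM.
Compound 3 `OC[C@H]1O[C@@H](n2cnc3c(NCc4c(F)ccc(F)c4F)ncnc32)[C@H](O)[C@@H]1O` has no result reported in this assay: compound 3 gives "not determined" (no result reported).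

Compound 2 thus stands at a limit in this assay, with one further entry also a limit and one entry without a number. Going by the values given here, the single measured step, a step that the two limits leave unreadable from compound 1 to compound 2, is 2-bromophenyl in place of 3-fluorophenyl on a saturated chain carbon bound to a nitrogen on an aromatic ring; its size is unreadable because of the limit of > 166000 nM in this assay, at which 2 of the 3 values shown sit.

Compound 4 `Cc1ccc(O)c(CNc2ncnc3c2ncn3[C@@H]2O[C@H](CO)[C@@H](O)[C@H]2O)c1` differs from compound 2 by 2-hydroxy-5-methylphenyl in place of 2-bromophenyl on a saturated chain carbon bound to a nitrogen on an aromatic ring. No readable measured step bears on this change, and both measured benzyl variants on the shared core gave only limits. The step from compound 2 to compound 4 in this assay is therefore expected to be a number no higher from compound 2 to compound 4 (the limit leaves the size open), with the value most likely remaining a limit. Compound 4 is estimated at 166000 nM, within 50000 nM to 500000 nM.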

Compound 4, half-maximal inhibitory concentration: > 166000 nM
Compound 4 was reported as a limit (the forecaster's own chance of this, stated with the estimate: 75%); the middle value lies on the limit itself.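

In this assay, going by these compounds alone, compound 4 gives > 166000 nM, which is a limit, and no step from compound 1 or compound 2 to compound 4 can be read. The compounds shown leave open whether any benzyl variant on the shared core reaches a measurable value in this assay.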